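A few compounds are considered here, and "the series" means these few. Any claim that something is new, unique, unknown or untested is made for them only; others in the source may bear on it.

Compound 1, `O=C(O)c1ccc(COc2ccc(/C=C3\SC(=S)N(c4ccc([N+](=O)[O-])cc4)C3=O)cc2)cc1`, in an assay on isolated protein for inhibition of Apoptosis regulator Bcl-2 (Homo sapiens), read by fluorescence polarization (on this read-out higher numbers stand for weaker inhibition and lower numbers for stronger inhibition), gives > 10000 nM, which is a limit of the assay and not a number.
Compound 2, `O=C(COc1ccc(/C=C2\SC(=S)N(c3ccc([N+](=O)[O-])cc3)C2=O)cc1)Nc1ccc(C(=O)O)cc1`, in this assay gives > 10000 nM, likewise a limit of the assay rather than a measured number.

Compound 1 therefore stands only at a limit, and compound 2 sits at the same limit, as both values shown do (the limit of > 10000 nM in this assay, at which 2 of the 2 values shown sit). Going by the values given here, the single measured step, a step that the two limits leave unreadable from compound 1 to compound 2, is unreadable because both ends are limits, so it gives no size in either direction.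

Compound 3, `CC(=O)c1ccc(N2C(=O)/C(=C/c3ccc(OCc4ccc(C(=O)O)cc4)cc3)SC2=S)cc1`, has not yet been measured. It differs from compound 1 by acetyl in place of nitro on an aromatic carbon. Among the compounds with values here, no measured pair touches this position, and the one measured step concerns a different part of the shared core and is itself unreadable. Nothing in the shown numbers points to a readable change for compound 3, so the step that the limit leaves unreadable from compound 1 to compound 3 is expected to be none that the assay could resolve. Compound 3 is therefore estimated at 20000 nM in this assay, within a range of 5000 nM to 100000 nM, most likely reported again only as a limit.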

Compound 3, inhibition constant: > 10000 nM
Compound 3 ended at the assay's limit (the forecaster's own chance of this, stated with the estimate: 75%); the middle value does not contradict the limit.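

In this assay compound 3 gives > 10000 nM, which is a limit of the assay and not a number. Compound 1 also stands at a limit, so no size can be read for the change from compound 1 to compound 3: the limit of > 10000 nM in this assay, at which 3 of the 3 values shown sit. The compounds shown leave open how acetyl and nitro compare in this assay, and what measured number any of the three compounds would give.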